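The source may hold more compounds than are shown below. What is called first, only, known or untested is meant among the compounds shown, and "the series" means these compounds.

Measured compounds in a functional assay on BCG823 cells (Homo sapiens) for inhibition, read by MTT assay, with a stated time of 72 h; on this read-out lower numbers stand for stronger inhibition and higher numbers for weaker inhibition:

Compound 1, `CN(C(=O)NC(=O)c1ccccc1F)c1nc(C(F)(F)F)c(C(=O)N/N=C/c2ccc(C(F)(F)F)cc2)s1`, gives 3.87 ug/mL.
Compound 2, `CN(C(=O)NC(=O)c1ccccc1F)c1nc(C(F)(F)F)c(C(=O)N/N=C/c2ccccc2C(F)(F)F)s1`, gives 4.67 ug/mL.
Compound 3, `CN(C(=O)NC(=O)c1ccccc1F)c1nc(C(F)(F)F)c(C(=O)N/N=C/c2cccc(C(F)(F)F)c2)s1`, gives 16.3 ug/mL.

Compound 2 holds the second highest of the three numbers in this assay: compound 1 lies within the scatter of it, seen in the step of a 1.2-fold higher number from compound 1 to compound 2 (0.08 log units; within the scatter), while compound 3 lies beyond it, as the step of a 3.5-fold higher number from compound 2 to compound 3 (0.54 log units; beyond the scatter) shows.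

Compound 4, `CN(C(=O)NC(=O)c1ccc(Cl)cc1Cl)c1nc(C(F)(F)F)c(C(=O)N/N=C/c2ccccc2C(F)(F)F)s1`, has not been measured. It differs from compound 2 in one place: 2,4-dichlorophenyl in place of 2-fluorophenyl on a carbonyl carbon.

All three measured steps, a 1.2-fold higher number from compound 1 to compound 2 (0.08 log units; within the scatter), a 4.2-fold higher number from compound 1 to compound 3 (0.62 log units; beyond the scatter) and a 3.5-fold higher number from compound 2 to compound 3 (0.54 log units; beyond the scatter), vary the trifluoromethylphenyl group on the carbon with a double bond to nitrogen, at the other end of the shared core. Among the compounds with values here, none of them touches the carbonyl carbon where compound 4 changes, so no measured step bears directly on this change. With no guide from the data, the expected step is none beyond the scatter, though the range must stay wide.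

Compound 4 is therefore estimated at 5 ug/mL, between 1.8 ug/mL and 14 ug/mL, a step of a 1.1-fold higher number from compound 2 to compound 4 (0.03 log units; within the scatter) expected from compound 2.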

Compound 4, half-maximal inhibitory concentration: 5.73 ug/mL
For compound 4 the middle estimate is 1.1-fold (0.06 log units) below the measured one; the measured number falls inside the stated range.
By their numbers in this assay, from the lowest: compounds 1, 2 and 4 (each within the scatter of the next); then compound 3.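

Within the data shown here, this is the first view of the carbonyl end of the molecule, and in this assay placing 2,4-dichlorophenyl on the carbonyl carbon instead of 2-fluorophenyl gives a 1.2-fold higher number from compound 2 to compound 4 (0.09 log units; within the scatter), so the two compounds cannot be told apart. Here, then, a change of aromatic substituents leaves the number within the scatter, whereas a change at the trifluoromethylphenyl end can go beyond it, as in a 4.2-fold higher number from compound 1 to compound 3 (0.62 log units; beyond the scatter). No other measurement accompanies this result that could account for it.

Among these compounds, only two groups have been compared at this position, so it remains open whether a phenyl ring carrying an amine or a carboxylic acid, or a longer chain in place of the ring, would be tolerated as well. Going by these compounds, it is also open whether 2,4-dichlorophenyl would give a similar result alongside the other trifluoromethylphenyl groups.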